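From Methyl Ester to Dimethyl Amide

The compounds below may be only part of what the source reports. "The series", "measured", "known", "first", "only" and "open" are said of these compounds alone.

Compound 1 (`O=C(O)COc1ccncc1-c1ccc2ccccc2c1`) gives "not determined" (no result reported)
Compound 2 (`COC(=O)/C=C/c1ccncc1-c1ccc2ccccc2c1`) gives 350 nM

Among the compounds with values here, in a functional assay on HCT-116 cells (Homo sapiens) for inhibition, read by MTT assay, with a stated time of 72 h (on this read-out higher numbers stand for weaker inhibition of growth and lower numbers for stronger inhibition of growth), compound 2 gives 350 nM and is the only compound with a number, so it has no rank yet. Compound 3 (`CN(C)C(=O)/C=C/c1ccncc1-c1ccc2ccccc2c1`) keeps the shared core but has dimethylamino in place of methoxy on a carbonyl carbon. Within the data shown here, no measured step shows what this swap does, so the expectation is only a modest move towards weaker inhibition, possibly none beyond the scatter. The step expected in this assay is a 2.3-fold higher number from compound 2 to compound 3 (0.36 log units; beyond the scatter) by this estimate. Compound 3 is estimated at 800 nM with a range from 250 nM to 2500 nM in this read-out.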

Compound 3, concentration for 50% growth inhibition: 4540 nM
Estimate against measurement, compound 3: 5.7-fold (0.75 log units) below, and the stated range ends below it.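

In this assay, putting dimethylamino in place of methoxy on a carbonyl carbon gives a 13-fold higher number from compound 2 to compound 3 (1.11 log units; beyond the scatter), so this position responds strongly to the change, and the methyl ester, compound 2, inhibits growth more strongly than the dimethyl amide. No measurement shown here accounts for the size of this step. From the compounds shown here alone, it remains open whether a carboxylic acid, a primary amide or an amide with a single methylamino group on this carbonyl carbon would lie closer to compound 2 or to compound 3.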